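Three thioether analogues, one propyl congener awaiting its reading

This account rests on a few compounds, and the source may have more. Where it says the series, first, only, none or still open, it means among the compounds named here.

The measured compounds:
Compound 1, `Cc1ccc(CSc2nc3nc(C)cc(Nc4cc(-c5ccccc5)[nH]n4)n3n2)cc1`, in an ADME assay on GES1 cells (Homo sapiens) for inhibition, read by MTT assay, with a stated time of 72 h (a higher number here means a weaker inhibitor, a lower number a stronger inhibitor), compound 1 gives 36200 nM.
Compound 2, `Cc1cc(Nc2cc(-c3ccccc3)[nH]n2)n2nc(SCc3nc4ccccc4[nH]3)nc2n1`, in this assay compound 2 gives 27800 nM.
Compound 3, `Cc1cc(Nc2cc(-c3ccccc3)[nH]n2)n2nc(SCc3ccc(C(F)(F)F)cc3)nc2n1`, in this assay compound 3 gives 42700 nM.

Compound 3 carries the highest number of the three, but the gaps are small: a 1.2-fold higher number from compound 1 to compound 3 (0.07 log units; within the scatter), and a 1.5-fold higher number from compound 2 to compound 3 (0.19 log units; within the scatter). Nothing therefore separates compound 3 from its two companions in this assay. Among the measured compounds shown here, the series so far varies only the group on the saturated chain carbon bound to the sulfur, and the two steps that exchange it, a 1.3-fold lower number from compound 1 to compound 2 (0.11 log units; within the scatter) and a 1.5-fold higher number from compound 2 to compound 3 (0.19 log units; within the scatter), both stay within the scatter, as does the change of a methyl to a trifluoromethyl on an aromatic carbon, a 1.2-fold higher number from compound 1 to compound 3 (0.07 log units; within the scatter).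

Compound 4, `CCCSc1nc2nc(C)cc(Nc3cc(-c4ccccc4)[nH]n3)n2n1`, is not yet measured. It differs from compound 3 at the same position that the measured steps probe: ethyl in place of 4-(trifluoromethyl)phenyl on a saturated chain carbon bound to a sulfur. The group that enters is far smaller than any tried so far, so the measured steps bear on it only loosely; still, because a 1.3-fold lower number from compound 1 to compound 2 (0.11 log units; within the scatter) and a 1.5-fold higher number from compound 2 to compound 3 (0.19 log units; within the scatter) show no movement beyond the scatter when this group changes, no step beyond the scatter is expected here either, in neither direction. Compound 4 is therefore expected to give 36000 nM, within a range from 15000 nM to 85000 nM. That estimate means an expected step of a 1.2-fold lower number from compound 3 to compound 4 (0.07 log units; within the scatter).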

Compound 4, half-maximal inhibitory concentration: > 50000 nM
Compound 4: only a limit was reported (the forecaster's own chance of this, stated with the estimate: 10%); at least 1.3-fold (0.14 log units) between middle value and limit.
By their numbers in this assay, from the lowest: compounds 2, 1 and 3 (each within the scatter of the next). At a limit, above all of these: compound 4.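

In this assay compound 4 gives > 50000 nM, which is a limit of the assay and not a number, and it is the only compound shown that ends at such a limit: the limit of > 50000 nM in this assay, at which 1 of the 4 values shown sits. The change to ethyl on a saturated chain carbon bound to a sulfur can therefore be read only as floors, namely an at least 1.1-fold higher number from compound 3 to compound 4 (0.06 log units; that floor lies within the scatter), an at least 1.3-fold higher number from compound 1 to compound 4 (0.14 log units; that floor lies within the scatter) and an at least 1.7-fold higher number from compound 2 to compound 4 (0.25 log units; that floor lies within the scatter). Among the compounds shown here, what the earlier compounds could not show is that a group with no ring at this position, far smaller than the three before it, brings no lower number, although every floor stays within the scatter and no real change is established.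

The compounds shown leave open how far compound 4 lies past its limit, and so whether the loss of the ring moves the number beyond the scatter at all. They also leave open whether a longer chain, such as hexyl, or a chain ending in an amine or a carboxylic acid, would read like ethyl or like the groups that carry a ring.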